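Changing the aryl group on a shared core

This account rests on a few compounds, and the source may have more. Where it says the series, first, only, none or still open, it means among the compounds named here.

In a functional assay on MCF7 cells (Homo sapiens) for cytotoxicity, read by MTT assay, with a stated time of 96 h (on this read-out higher numbers stand for weaker inhibition and lower numbers for stronger inhibition), compound 1 `COc1cc(C(=O)c2cn(-c3ccccc3)cc2-c2ccccc2C)cc(OC)c1OC` gives 190 nM and compound 2 `COc1cc(C(=O)c2cn(-c3ccccc3)cc2-c2ccc(Cl)cc2)cc(OC)c1OC` gives 290 nM, so compound 2 stands within the usual scatter of compound 1. For the measured compounds named here, the only measured step, a 1.5-fold higher number from compound 1 to compound 2 (0.18 log units; within the scatter), exchanges 2-methylphenyl for 4-chlorophenyl. Compound 3 `COc1cc(C(=O)c2cn(-c3ccccc3)cc2-c2ccccc2Br)cc(OC)c1OC`, not yet measured, has 2-bromophenyl in place of 4-chlorophenyl on an aromatic carbon. With a single small step as the guide, no change beyond the scatter is expected in this assay. The expected move is a 1.4-fold lower number from compound 2 to compound 3 (0.14 log units; within the scatter). Compound 3 is estimated at 210 nM, within an expected range of 80 nM to 550 nM.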

Compound 3, half-maximal inhibitory concentration: 190 nM
Compound 3: the middle estimate sits 1.1-fold (0.04 log units) above what was measured; measured number inside the range.
By their numbers in this assay, from the lowest: compounds 1, 3 and 2 (each within the scatter of the next).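

Swapping 4-chlorophenyl for 2-bromophenyl gives a 1.5-fold lower number from compound 2 to compound 3 (0.18 log units; within the scatter) in this assay, and bromo in place of methyl gives no change at the digits printed from compound 1 to compound 3 (within the scatter) on the shared core. This position has therefore now carried three different substituted phenyl groups with every step inside the scatter, so these exchanges do not separate the compounds. No measurement at hand gives a reason for this.

Still open, from the compounds shown here alone, is whether an amine, a carboxylic acid or a longer alkyl chain on this phenyl would leave the number equally unmoved.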